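Lengthening an Ester Chain Beyond an Inactive Compound

This account rests on a few compounds, and the source may have more. Where it says the series, first, only, none or still open, it means among the compounds named here.

- Compound 1 `CCC(=O)OC[C@H]1O[C@@H](O[C@@H]2OC=C(C(=O)OC)[C@H]3C[C@H](OC(C)=O)[C@H](C)[C@@H]23)[C@H](OC(C)=O)[C@@H](OC(C)=O)[C@@H]1OC(C)=O` gives 2.85 ug/mL
- Compound 2 `CCCCCCCCCCCC(=O)OC[C@H]1O[C@@H](O[C@@H]2OC=C(C(=O)OC)[C@H]3C[C@H](OC(C)=O)[C@H](C)[C@@H]23)[C@H](OC(C)=O)[C@@H](OC(C)=O)[C@@H]1OC(C)=O` gives 0.42 ug/mL
- Compound 3 `CCCCCCCCCCCCCC(=O)OC[C@H]1O[C@@H](O[C@@H]2OC=C(C(=O)OC)[C@H]3C[C@H](OC(C)=O)[C@H](C)[C@@H]23)[C@H](OC(C)=O)[C@@H](OC(C)=O)[C@@H]1OC(C)=O` gives "not active" (no number reported)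

These results come from a functional assay on Caco-2 cells (Homo sapiens) for cytotoxicity, read by MTT assay, with a stated time of 4 h (on this read-out higher numbers stand for weaker inhibition and lower numbers for stronger inhibition), and they leave compound 3 without a number, so its place on the scale cannot be fixed. Compound 4 `CCCCCCCCCCCCCCCC(=O)OC[C@H]1O[C@@H](O[C@@H]2OC=C(C(=O)OC)[C@H]3C[C@H](OC(C)=O)[C@H](C)[C@@H]23)[C@H](OC(C)=O)[C@@H](OC(C)=O)[C@@H]1OC(C)=O` differs from compound 3 by ethyl in place of hydrogen on a saturated chain carbon, ten or more bonds along the chain from a carbonyl carbon and so carries a still longer ester chain.

For the measured compounds named here, only one measured step bears on this change. Nonyl in place of hydrogen gave a 6.8-fold lower number from compound 1 to compound 2 (0.83 log units; beyond the scatter) and this modest step points toward stronger inhibition. Compound 3 goes against that trend, since its chain is longer than that of compound 2 and yet it has no number. The step from compound 3 therefore has no size that can be calculated, and the same direction cannot be assumed. Compound 4 is expected most likely to remain without a number, and any number it does give is expected to show weaker inhibition than compound 2 at 0.42 ug/mL in this test. For compound 4 the estimated value is 4 ug/mL with an expected range from 0.6 ug/mL to 30 ug/mL if a number is reported at all.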

Compound 4, half-maximal inhibitory concentration: "not active" (no number reported)
For compound 4 the study gives words and no number, so the estimate cannot be set against anything.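

In this assay, for the compounds shown here, compound 3 and compound 4 are both reported as "not active" without a number, so no step between them can be read. No measurement shown offers an explanation for this result. Still open, going by these compounds, is how far each compound lies from compound 2 at 0.42 ug/mL on this scale.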